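The source may hold more compounds than are shown below. What is called first, only, known or untested is meant among the compounds shown, and "the series" means these compounds.

Series notes. In an assay on membranes from brain for displacement of a labelled ligand from Sigma non-opioid intracellular receptor 1 (Cavia porcellus), read by scintillation counting, with a stated time of 90 min (a lower number here means a stronger inhibitor, a higher number a weaker inhibitor), compound 3 `COc1cc2c(cc1OC)CN(CCCCNC(=O)c1ccc(-c3cn(CCOCCF)nn3)cc1)CC2` gives 14700 nM and holds the lowest number of the three measured; compound 1 `COc1cccc(-n2cc(C(=O)NCCCCN3CCc4cc(OC)c(OC)cc4C3)nn2)c1` gives 20200 nM, within the scatter of that, while compound 2 `COc1cc2c(cc1OC)CN(CCCCNC(=O)c1cn(Cc3cccc(OCCF)c3)nn1)CC2` gives 46300 nM, beyond it. Going by the values given here, the only single-point step measured is a 2.3-fold higher number from compound 1 to compound 2 (0.36 log units; beyond the scatter). Compound 4 `COc1ccccc1Cn1cc(-c2ccc(C(=O)NCCCCN3CCc4cc(OC)c(OC)cc4C3)cc2)nn1` differs from compound 3 by 2-methoxyphenyl in place of (2-fluoroethoxy)methyl on a saturated chain carbon bound to an aromatic nitrogen; read one bond further out, 2-(2-fluoroethoxy)ethyl becomes 2-methoxybenzyl. The step from compound 1 to compound 2 swapped a methoxyphenyl for a fluoroethoxy-bearing benzyl and cost a modest amount; the present change runs the other way, so a small lowering is expected, a 1.6-fold lower number from compound 3 to compound 4 (0.21 log units; within the scatter), though a change near the scatter is just as plausible. Compound 4 is estimated at 9000 nM, with a range of 3500 nM to 25000 nM.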

Compound 4, inhibition constant: 8580 nM
Compound 4: middle estimate off by 1.0-fold (0.02 log units), on the high side, and the stated range covers the measured number.
By their numbers in this assay, from the lowest: compounds 4, 3 and 1 (each within the scatter of the next, the first and the last beyond it); then compound 2.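

On a saturated chain carbon bound to an aromatic nitrogen, 2-methoxyphenyl in place of (2-fluoroethoxy)methyl gives a 1.7-fold lower number from compound 3 to compound 4 (0.23 log units; within the scatter) in this assay. This pair therefore shows that an aromatic ring can replace the open fluorinated ether chain at this place without a shift beyond the scatter, and that the fluorine is not required to hold the number at this level. Nothing available explains this result.

Open, on these data alone, is whether an unsubstituted benzyl or a pyridylmethyl group here would move the number beyond the scatter of compound 4. The contribution of the methoxy group on the new ring also remains unresolved.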